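Moving the methyl group around a benzyl ring

The source may report more compounds than this note shows. Statements on the series, on what has been measured and on what is new or still open speak of the compounds shown alone.

Of the compounds shown here, two with a shared core have been measured in an assay on Prostate gland for inhibition of steroid 5-alpha-reductase (Rattus norvegicus); on this read-out lower numbers stand for stronger inhibition and higher numbers for weaker inhibition. Compound 1 `CCCC(C(C)C)n1ccc2cc(/C(C)=C/C(=O)Nc3ccccc3OCCCC(=O)O)ccc21` gives 7.2 nM. Within the data shown here, compound 2 `C/C(=C\C(=O)Nc1ccccc1OCCCC(=O)O)c1ccc2c(ccn2Cc2cccc(C)c2)c1` gives 250 nM, the highest of the two numbers, and the step of a 35-fold higher number from compound 1 to compound 2 (1.54 log units; beyond the scatter) is the only measured step so far. Compound 3 `C/C(=C\C(=O)Nc1ccccc1OCCCC(=O)O)c1ccc2c(ccn2Cc2ccc(C)cc2)c1` differs from compound 2 by 4-methylphenyl in place of 3-methylphenyl on a saturated chain carbon bound to an aromatic nitrogen. Among the measured compounds shown here, no measured step shifts a methyl group from one position to another on this ring; the one known step swaps a branched alkyl chain for a benzyl group and is large, but it does not speak directly to the change at hand. With nothing pointing one way or the other, the step from compound 2 to compound 3 is expected to stay within the usual scatter, no change at the digits printed from compound 2 to compound 3 (within the scatter). Compound 3 is therefore estimated at 250 nM, with a range from 80 nM to 800 nM.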

Compound 3, half-maximal inhibitory concentration: 88 nM
The estimate for compound 3 lay 2.8-fold (0.45 log units) above the measured number, within the range that was stated.
By their numbers in this assay, from the lowest: compound 1; then compound 3; then compound 2.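

In this assay, the same atoms joined differently give a 2.8-fold lower number from compound 2 to compound 3 (0.45 log units; beyond the scatter) on the benzyl group, so the place of a single methyl group on this ring changes the read-out, something the earlier swap of a whole group could not show. The shift is modest, and 4-methylbenzyl in place of 1-isopropylbutyl on the aromatic nitrogen still leaves a 12-fold higher number from compound 1 to compound 3 (1.09 log units; beyond the scatter) in the same read-out, so this better of the two benzyl groups does not close the gap to the branched chain. No outside evidence on this position is available to account for the difference between the two methyl placements.

Going by these compounds, it remains open whether a chlorine atom or a methoxy group in place of the methyl of 4-methylbenzyl would lower the number further. Also open, on these data alone, is whether a plain butyl chain on the aromatic nitrogen would come closer to compound 1.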